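Moving the Phenyl Out by One Carbon

This account rests on a few compounds, and the source may have more. Where it says the series, first, only, none or still open, it means among the compounds named here.

In an assay on CHO cells for antagonist activity at transient receptor potential cation channel subfamily V member 1 (Homo sapiens), read by FLIPR (on this read-out lower numbers stand for stronger inhibition and higher numbers for weaker inhibition), compound 1 `CS(=O)(=O)Nc1ccc(C(C(=O)NCc2ccc(C(F)(F)F)nc2SC2CCCCC2)c2cccc(F)c2)cc1F` gives 48.7 nM. Compound 2 `Cc1ccccc1C(C(=O)NCc1ccc(C(F)(F)F)nc1SC1CCCCC1)c1ccc(NS(C)(=O)=O)c(F)c1` shares the same core but carries a 2-methylphenyl on the saturated chain carbon; in this assay compound 2 is reported only as "active" (no number reported), so no single number fixes where it stands, and no comparison with compound 1 can be drawn from it. Compound 3 `CS(=O)(=O)Nc1ccc(C(Cc2ccccc2)C(=O)NCc2ccc(C(F)(F)F)nc2SC2CCCCC2)cc1F` has not been measured in this assay. The change is benzyl in place of 2-methylphenyl on a saturated chain carbon bound to an aromatic carbon and a carbonyl carbon; the two compounds hold the same atoms, only joined differently. Without a measured pair that isolates this change, the size of the step in this assay is open, though the fresh placement of the ring could move the number either way, possibly beyond the usual scatter. On this basis compound 3 is expected to give 150 nM in this assay, within a range of 40 nM to 600 nM.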

Compound 3, inhibition constant: "active" (no number reported)
For compound 3 the study gives words and no number, so the estimate cannot be set against anything.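

Going by these compounds alone, compound 2 and compound 3 are both reported only as active, without a number, so no step between them can be read. Going by these compounds, whether benzyl in place of 2-methylphenyl strengthens or weakens inhibition, and by how much, stays open. No evidence bears on this result.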